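A few compounds are considered here, and "the series" means these few. Any claim that something is new, unique, unknown or untested is made for them only; others in the source may bear on it.

Measured so far:
Compound 1 `C=CC1=C(C(=O)NCCC)C(c2ccc(F)cc2)OC1` gives > 100000 nM in a functional assay on HeLa cells (Homo sapiens) for cytotoxicity, read by MTT assay, with a stated time of 24 h (on this read-out lower numbers stand for stronger inhibition and higher numbers for weaker inhibition), which is a limit of the assay and not a number.
Compound 2 `C=CC1=C(C(=O)NC2CCCCC2)C(c2ccc(OC)cc2)OC1` gives 24800 nM in this assay.

Within the data shown here, compound 2 stands as the only compound with a number on this read-out; the other value shown, that of compound 1, is a limit of > 100000 nM in this assay, at which 1 of the 2 values shown sits, rather than a measured figure, so no measured step between the two can be drawn, and only their two values can be set side by side.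

Compound 3 `C=CC1=C(C(=O)NC2CCCCC2)C(c2ccc(F)cc2)OC1` has not yet been measured. It differs from compound 2 in one place: fluoro in place of methoxy on an aromatic carbon. The cyclohexyl amide of compound 2 is kept.

Among the measured compounds shown here, no step between measured compounds has been established here, so the size of the move from compound 2 to compound 3 can only be guessed. Given that compound 1, which also carries the fluoro, gave only a limit, the expected step of a 2.2-fold higher number from compound 2 to compound 3 (0.35 log units; beyond the scatter) is towards weaker inhibition, likely beyond the usual scatter. Compound 3 is therefore estimated at 55000 nM, with a plausible range from 15000 nM to 200000 nM.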

Compound 3, half-maximal inhibitory concentration: > 100000 nM
Compound 3: only a limit was reported; the forecaster's own chance of this, stated with the estimate: 40%; middle value at least 1.8-fold (0.25 log units) away from the limit.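

In this assay, replacing the methoxy of the 4-methoxyphenyl group with fluoro while keeping the cyclohexyl amide gives an at least 4.0-fold higher number from compound 2 to compound 3 (0.60 log units; beyond the scatter), the first readable sign that the group at this place on the aromatic ring matters for this read-out. Compound 1 and compound 3 both carry the 4-fluorophenyl group and differ only in propyl against cyclohexyl on the amide nitrogen, but the step between them cannot be read, so the cyclohexyl amide alone does not bring a fluoro compound into measurable range. Compound 3 gives a limit of the assay rather than a number, so the step from the methoxy compound sets only a minimum size and the true gap remains unknown: the limit of > 100000 nM in this assay, at which 2 of the 3 values shown sit.

With only methoxy and fluoro shown at this place, it remains open whether the methoxy itself is needed or whether another group, such as an ethoxy, a hydroxyl or an amine, would serve as well or better. On these data alone, it is also open whether methoxy would give a measurable number with the propyl amide, or whether it does so only alongside cyclohexyl.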